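This account rests on a few compounds, and the source may have more. Where it says the series, first, only, none or still open, it means among the compounds named here.

Compound 1 `CCC(=O)N(c1ccc(OC)cc1)C1CCCC1N(C)C`: 30 mg/kg; 30 mg/kg (2 entries)
Compound 2 `CCC(=O)N(c1ccc(C)cc1)C1CCCC1N(C)C`: 30 mg/kg; 30 mg/kg (2 entries)
Compound 3 `CCC(=O)N(c1ccc(C(F)(F)F)cc1)C1CCCC1N(C)C`: 10 mg/kg

These three compounds were tested in a functional assay on the whole organism for positive allosteric modulation, with Mus musculus as the target; on this read-out lower numbers stand for an effect already at smaller amounts and higher numbers for an effect only at larger amounts of compound. Compound 3 stands at 10 mg/kg, a lower number than compound 1 at 30 mg/kg; 30 mg/kg (2 entries) and compound 2 at 30 mg/kg; 30 mg/kg (2 entries). Its result is a single entry, while compound 1 and compound 2 each have two.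

Compound 4 `CCC(=O)N(c1ccc([N+](=O)[O-])cc1)C1CCCC1N(C)C` has not yet been measured. It has nitro in place of trifluoromethyl on an aromatic carbon, and the rest of the structure is unchanged. Among the compounds with values here, no measured pair in this set differs in one place only, so the data give no direct guide to the size of this step. The expectation therefore starts from compound 3 at 10 mg/kg. In this assay, the expected step, a 1.5-fold higher number from compound 3 to compound 4 (0.18 log units; within the scatter), stays within the usual scatter, leaning slightly toward a higher number. For compound 4 the estimated value is 15 mg/kg, with an expected range from 6 mg/kg to 40 mg/kg.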

Compound 4, dose for half-maximal effect: 20 mg/kg
The estimate for compound 4 lay 1.3-fold (0.12 log units) below the measured number; low and high end bracket the measured number.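

In this assay, within the data shown here, the step of a 2.0-fold higher number from compound 3 to compound 4 (0.30 log units; within the scatter) gives the first direct reading at this position, on an aromatic carbon para to a large group, where one group is exchanged and the rest of the structure stays the same. It shows that nitro, which brings 2 hydrogen-bond acceptors, can take the place of trifluoromethyl, which brings none, with no difference that can be told from the usual spread of repeated measurements. The data shown offer no measurement that would explain this outcome.

From the compounds shown here alone, it remains open how an amine or a carboxylic acid would read on this same aromatic carbon, or how the compounds would read with plain hydrogen there. Also open, going by these compounds, is the effect of a longer chain on the amide carbonyl, with nitro or trifluoromethyl kept in place.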